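Methoxy on the core-bound phenyl of compound 1

The source may report more compounds than this note shows. Statements on the series, on what has been measured and on what is new or still open speak of the compounds shown alone.

Compound 1 `O=C(NOCc1ccccc1)c1cn(-c2ccccc2)nc1-c1ccccc1` gives 5000 nM in a functional assay on A549 cells (Homo sapiens) for antiproliferative activity, read by MTT assay, with a stated time of 48 h, in the presence of a further agent that is not named here (a lower number here means a stronger inhibitor of growth, a higher number a weaker inhibitor of growth), the lowest of the three numbers in hand, though within the scatter of the other two. Compound 2 `O=C(NOCc1ccccc1F)c1cn(-c2ccccc2)nc1-c1ccccc1` gives 5940 nM and compound 3 `O=C(NOCc1ccc(Cl)cc1Cl)c1cn(-c2ccccc2)nc1-c1ccccc1` gives 7350 nM; the steps of a 1.2-fold higher number from compound 1 to compound 2 (0.07 log units; within the scatter) and a 1.5-fold higher number from compound 1 to compound 3 (0.17 log units; within the scatter) both sit within the scatter, as does a 1.2-fold higher number from compound 2 to compound 3 (0.09 log units; within the scatter). Compound 4 `COc1ccc(-c2nn(-c3ccccc3)cc2C(=O)NOCc2ccccc2)cc1` carries methoxy in place of hydrogen on an aromatic carbon, para to a large group on the phenyl bound to the core, not on the benzyl group. No measured step touches that ring; the three steps shown all alter the benzyl ring and none moved the number beyond the scatter. The change to compound 4 is therefore expected to stay within the scatter, a 1.1-fold higher number from compound 1 to compound 4 (0.04 log units; within the scatter). Compound 4 is estimated at 5500 nM, within 2500 nM to 12000 nM.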

Compound 4, concentration for 50% growth inhibition: 1940 nM
Compound 4: the middle estimate sits 2.8-fold (0.45 log units) above what was measured; measured number outside the range, below it.
By their numbers in this assay, from the lowest: compound 4; then compounds 1, 2 and 3 (each within the scatter of the next).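

Among these compounds, the phenyl bound to the core responds where the benzyl ring did not: in this assay the change from phenyl to 4-methoxyphenyl gives a 2.6-fold lower number from compound 1 to compound 4 (0.41 log units; beyond the scatter) and is the only step beyond the scatter. Among the compounds shown here, all three benzyl-ring steps stayed within the scatter, so this is the first position seen to move the number, though only modestly. Nothing measured here accounts for the step.

Open, from the compounds shown here alone, is whether methoxy itself matters or whether a hydroxyl, chlorine or dimethylamino group at this place would do the same. Also open, going by these compounds, is whether the step would carry over to the benzyl rings of compound 2 and compound 3.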